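The source may hold more compounds than are shown below. What is called first, only, known or untested is meant among the compounds shown, and "the series" means these compounds.

Compound 2, with the structure `Cc1cc(C(=O)O)ccc1CN1CCC[C@H](O[C@H](CO)c2ccccc2)[C@@H]1c1ccccc1`, sits at the weak end of the three measured compounds. In an assay on isolated protein for activation of cGMP-dependent protein kinase 1 (Homo sapiens), read by ADP-Glo, with stated times of 30 min and 2 h, in the presence of a further agent that is not named here (a higher number here means that more compound is needed for the effect, a lower number that less compound is needed), compound 2 gives 25000 nM, the highest of the three numbers. Its nearest neighbour is compound 1, `COC(=O)c1ccc(CN2CCC[C@H](O[C@H](CO)c3cc(Cl)cc(Cl)c3)[C@@H]2c2ccccc2)c(C)c1`, which in this assay gives 900 nM; the gap between them is well beyond the scatter. Further away lies compound 3, `Cc1cc(C(=O)O)ccc1CN1CCC[C@H](O[C@@H](CC(C)(C)O)c2cc(Cl)cc(Cl)c2)[C@@H]1c1ccccc1`, which in this assay gives 330 nM, again far beyond the scatter from compound 2. Neither compound 1 nor compound 3 differs from compound 2 in only one place, so no single step between measured compounds is shown, and only the two values of each pair can be set side by side.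

Compound 4, `Cc1cc(C(=O)O)ccc1CN1CCC[C@H](O[C@H](CO)c2ccnc(Cl)c2)[C@@H]1c1ccccc1`, has not yet been measured. It differs from compound 2 in one place: 2-chloropyridin-4-yl in place of phenyl on a saturated chain carbon bound to an oxygen on a saturated carbon and a saturated chain carbon. For this change a step in this assay in the direction of a lower number is expected, of moderate size, going beyond the scatter, because compound 1 with 900 nM and compound 3 with 330 nM both stand far below compound 2. On that basis compound 4 is estimated to give 5000 nM in this assay, within a range from 1500 nM to 15000 nM, which would mean an expected step of a 5.0-fold lower number from compound 2 to compound 4 (0.70 log units; beyond the scatter).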

Compound 4, half-maximal effective concentration: 50000 nM
Beside the measured number, compound 4's estimate is 10-fold (1.00 log units) below it, outside the stated range (above it).
By their numbers in this assay, from the lowest: compound 3; then compound 1; then compounds 2 and 4 (each within the scatter of the next).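

In this assay, within the data shown here, the change gives a 2.0-fold higher number from compound 2 to compound 4 (0.30 log units; within the scatter) and is the first step between measured compounds that differ in one place, so it offers the first direct reading at this saturated chain carbon. Replacing phenyl with 2-chloropyridin-4-yl brings in a ring nitrogen, a chlorine and one hydrogen-bond acceptor, yet the two compounds remain within the scatter of each other, and this exchange does not separate them in this assay. Nothing available here accounts for this outcome.

The chlorine and the ring nitrogen enter together, so the compounds shown cannot tell what each does alone, and a pyridinyl group without chlorine or a chlorophenyl group without a ring nitrogen would be needed to pull them apart. On these data alone, it also remains open whether a ring carrying an amine or a carboxylic acid at this place would read any differently, and whether 2-chloropyridin-4-yl would leave the number equally unmoved on the core of compound 3, with its longer hydroxyl-bearing chain.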